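From tert-butyl to methylsulfanyl, double bond unchanged

This account rests on a few compounds, and the source may have more. Where it says the series, first, only, none or still open, it means among the compounds named here.

In a functional assay on SK-MEL-5 cells (Homo sapiens) for cytotoxicity (on this read-out higher numbers stand for an effect only at larger amounts of compound and lower numbers for an effect already at smaller amounts), compound 1 (`COc1cc(/C=C\c2ccc(C(C)(C)C)cc2)cc(OC)c1OC`) gives 2.1 uM and compound 2 (`CCOc1ccc(/C=C/c2cc(OC)c(OC)c(OC)c2)cc1`) gives 1.17 uM, two values within the scatter of each other. Compound 3 (`COc1cc(/C=C/c2ccc(C(C)(C)C)cc2)cc(OC)c1OC`) gives > 25 uM, which is a limit and not a number.

Compound 4 (`COc1cc(/C=C\c2ccc(SC)cc2)cc(OC)c1OC`) keeps the Z double bond of compound 1 and changes one group (methylsulfanyl in place of tert-butyl on an aromatic carbon). For the measured compounds named here, two measured steps bear on this. Turning only the double bond from Z to E brings an at least 11-fold higher number from compound 1 to compound 3 (1.07 log units; beyond the scatter), a large step that goes with the fact that compounds 1 and 3 differ only in the configuration as drawn and does not apply here, since the Z form stays. Tert-butyl in place of ethoxy brings an at least 21-fold higher number from compound 2 to compound 3 (1.32 log units; beyond the scatter), also large, though seen with the E double bond. Going by the values given here, both sizes are lower bounds because of the limit of > 25 uM in this assay, at which 1 of the 3 values shown sits, and no measured compound carries methylsulfanyl, so the size of the new step is uncertain.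

With tert-butyl leaving, a lower number is expected, estimated as a 5.3-fold lower number from compound 1 to compound 4 (0.72 log units; beyond the scatter) in this assay and thus a moderate gain. Compound 4 is expected at 0.4 uM with an estimated range from 0.05 uM to 2.5 uM for this measurement.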

Compound 4, concentration for half-maximal effect: 4 uM
Compound 4: the middle estimate sits 10-fold (1.00 log units) below what was measured; the whole stated range lies below it.
By their numbers in this assay, from the lowest: compounds 2, 1 and 4 (each within the scatter of the next, the first and the last beyond it). At a limit, above all of these: compound 3.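

In this assay, methylsulfanyl in place of tert-butyl on this aromatic carbon, with the Z double bond kept, gives a 1.9-fold higher number from compound 1 to compound 4 (0.28 log units; within the scatter). This is the only step shown at this position on the Z double bond, and on it the two groups cannot be told apart, even though tert-butyl has 4 heavy atoms and methylsulfanyl has 2, one of them sulfur. The earlier step at this position, an at least 21-fold higher number from compound 2 to compound 3 (1.32 log units; beyond the scatter), was seen on the E double bond and gives only a lower bound for its size, because of this: the limit of > 25 uM in this assay, at which 1 of the 4 values shown sits.

The compounds shown leave open how methylsulfanyl behaves on the E double bond. They also leave open whether an amine or a carboxylic acid on this aromatic carbon would stay within the scatter of compound 1.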